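This account rests on a few compounds, and the source may have more. Where it says the series, first, only, none or still open, it means among the compounds named here.

Working notes on the series.

Compound 1 `Cc1ccc(CC(C)C(=O)N2CCN(c3ccc(C(F)(F)F)cc3[C@@H](N)CC(C)C)CC2)cc1C` is one of three compounds with a number in an assay on HEK293 cells for displacement of a labelled ligand from Melanocortin receptor 4 (Homo sapiens); on this read-out lower numbers stand for stronger inhibition and higher numbers for weaker inhibition; compound 1 gives 240 nM. Compound 3 `Cc1cc(CC(C)C(=O)N2CCN(c3ccc(C(F)(F)F)cc3[C@@H](N)CC(C)C)CC2)ccc1Cl` gives 71 nM in this assay, and compound 2 `COc1ccc(OCC(=O)N2CCN(c3ccc(C(F)(F)F)cc3[C@@H](N)CC(C)C)CC2)cc1` gives 3800 nM. Among the three, compound 1 stands second highest: the step of a 3.4-fold lower number from compound 1 to compound 3 (0.53 log units; beyond the scatter) is modest, while a 16-fold higher number from compound 1 to compound 2 (1.20 log units; beyond the scatter) is large.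

Compound 4 `CC(C)C[C@H](N)c1cc(C(F)(F)F)ccc1N1CCN(C(=O)CCC(N)=O)CC1` has not been measured. It differs from compound 1 in one place: 2-carbamoylethyl in place of 1-(3,4-dimethylbenzyl)ethyl on a carbonyl carbon

The step that bears on this is a 16-fold higher number from compound 1 to compound 2 (1.20 log units; beyond the scatter), where the 1-(3,4-dimethylbenzyl)ethyl group was exchanged for a group that still carries a six-membered aromatic ring. In compound 4 the aromatic ring is gone altogether, and what enters is a short chain of five heavy atoms with a hydrogen-bond donor and acceptor. A step at least as large as that seen for compound 2, and in the same direction, is therefore expected. The estimate for compound 4 in this assay is 6000 nM, with a range from 1500 nM to 25000 nM, meaning an expected step of a 25-fold higher number from compound 1 to compound 4 (1.40 log units; beyond the scatter).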

Compound 4, inhibition constant: > 10000 nM
Compound 4: no number, only a limit; the forecaster's own chance of this, stated with the estimate: 30%; at least 1.6-fold (0.22 log units) between middle value and limit.
By their numbers in this assay, from the lowest: compound 3; then compound 1; then compound 2. At a limit, above all of these: compound 4.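

In this assay compound 4 gives > 10000 nM, which is a limit and not a number. With 2-carbamoylethyl on the carbonyl carbon, the readings are an at least 41-fold higher number from compound 1 to compound 4 (1.61 log units; beyond the scatter) and an at least 140-fold higher number from compound 3 to compound 4 (2.14 log units; beyond the scatter), so a chain with no ring does not retain the binding seen with the two branched benzyl-type groups. Compounds 1, 2 and 3 all keep a six-membered aromatic ring here, and the comparison with the weakest of them, an at least 2.6-fold higher number from compound 2 to compound 4 (0.42 log units; beyond the scatter), shows that this change goes further than the exchange to the (4-methoxyphenoxy)methyl group.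

The compounds shown do not separate the absence of the ring from the presence of the terminal carbamoyl group. Going by these compounds, a plain alkyl chain, or a chain ending in an amine or a carboxylic acid, would bear on this, and the true size of the step remains open behind the limit.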